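The compounds below may be only part of what the source reports. "The series", "measured", "known", "first", "only" and "open" are said of these compounds alone.

Of the compounds shown here, three built on one shared core have been measured in a functional assay on the whole organism (Central nervous system) for activation, with Mus musculus as the target; a lower number here means that less compound is needed, a higher number that more compound is needed for the effect. Compound 1 `O=C(CCC(=O)c1ccc(F)cc1)NCCCO` gives 300 mg/kg. Compound 2 `Cc1ccc(C(=O)CCC(=O)NCCCO)c(C)c1` gives 150 mg/kg. Compound 3 `COc1ccc(C(=O)CCC(=O)NCCCO)cc1` gives 150 mg/kg, level with compound 2 at the digits shown, so that these two together hold the lowest numbers of the three, while compound 1 is the furthest from compound 3. Among the measured compounds shown here, the one step between measured compounds that differ in a single place, a 2.0-fold lower number from compound 1 to compound 3 (0.30 log units; within the scatter), lies within the scatter.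

The next compound, compound 4 `Cc1ccc(C(=O)CCC(=O)NCCCO)cc1`, differs from compound 3 by a single change: methyl in place of methoxy on an aromatic carbon, para to a large group. For the measured compounds named here, only one measured step touches this position, and that is the exchange of fluoro for methoxy from compound 1 to compound 3, which stayed within the scatter. Compound 2 also bears a methyl at the same carbon, along with a second methyl, and its value and that of compound 3 are the same at the digits shown. A step of no change at the digits printed from compound 3 to compound 4 (within the scatter) is therefore expected in this assay, none beyond the scatter. Compound 4 is estimated at 150 mg/kg, with a range from 75 mg/kg to 300 mg/kg.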

Compound 4, dose for half-maximal effect: 300 mg/kg
The estimate for compound 4 lay 2.0-fold (0.30 log units) below the measured number, and the stated range covers the measured number.
By their numbers in this assay, from the lowest: compounds 2, 3, 1 and 4 (each within the scatter of the next).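

In this assay this aromatic carbon, para to a large group, has now carried methoxy, methyl and fluoro, and the steps that join them, a 2.0-fold higher number from compound 3 to compound 4 (0.30 log units; within the scatter) and no change at the digits printed from compound 1 to compound 4 (within the scatter), do not leave the scatter. Exchanging methoxy for methyl takes away one heavy atom and the one hydrogen-bond acceptor of the group, yet this exchange is not told apart from no change in this assay. The second methyl of compound 2 can also be read alone for the first time, since taking it away gives a 2.0-fold higher number from compound 2 to compound 4 (0.30 log units; within the scatter), so that this position and this further place on the ring both remain without a step beyond the scatter among the compounds shown.

The compounds shown leave open whether an amine or a carboxylic acid on this aromatic carbon would give a step beyond the scatter, and the same question stands for a longer chain in place of the one on the amide nitrogen. Nor do they tell whether any such step would appear with the shared core otherwise unchanged. No evidence at hand bears on these values.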